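The compounds below may be only part of what the source reports. "The series", "measured", "known", "first", "only" and "open" are said of these compounds alone.

Measured in a functional assay on A549 cells (Homo sapiens) for cytotoxicity; a higher number here means a weaker inhibitor, a lower number a stronger inhibitor:

Compound 1 `O=C1NC(c2ccc(Br)cc2)CN1S(=O)(=O)c1ccc2c(c1)CCC2`: 33900 nM
Compound 2 `O=C1NC(c2ccccc2)CN1S(=O)(=O)c1ccccc1`: 145000 nM

For the measured compounds named here, only two numbers are available so far. Compound 1 has the lower one, which makes it the stronger inhibitor of the pair, and the gap to compound 2 lies beyond the usual scatter of repeat measurements. Both numbers are high, so neither compound is a strong inhibitor in this assay.

The next compound keeps everything in compound 1 except the halogen. Compound 3 `O=C1NC(c2ccccc2)CN1S(=O)(=O)c1ccc2c(c1)CCC2` has hydrogen in place of bromo on an aromatic carbon, so 4-bromophenyl becomes phenyl (hydrogen in place of bromo on an aromatic carbon). Going by the values given here, no two measured compounds differ in this one place alone, so the data give no direct size for this change. Among the compounds with values here, the only guide is that compound 2, which also carries the phenyl, reads 145000 nM. A moderate rise in the number, towards weaker inhibition, is therefore expected, and the expected step is a 2.1-fold higher number from compound 1 to compound 3 (0.31 log units; beyond the scatter). For compound 3 the estimated value is 70000 nM, with an expected range of 30000 nM to 160000 nM.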

Compound 3, half-maximal inhibitory concentration: 910 nM
For compound 3 the middle estimate is 77-fold (1.89 log units) above the measured one; the measured number lies below the stated range.
By their numbers in this assay, from the lowest: compound 3; then compound 1; then compound 2.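

In this assay, the aromatic carbon para to a large group turns out to be a very sensitive place: putting hydrogen in place of bromo gives a 37-fold lower number from compound 1 to compound 3 (1.57 log units; beyond the scatter), a large step, so in this pair the compound without the bromo is by far the stronger inhibitor. The phenyl does not set the number on its own, since compound 2 also carries it and gives 145000 nM, while compound 3 gives 910 nM; these two compounds differ elsewhere in the molecule, so what lies there matters as well. Nothing available explains why removing the bromo has so large an effect.

Going by these compounds, it remains open whether bromo is a special case or whether other groups at this carbon, such as fluoro, methoxy or an amine, would read closer to compound 1 or to compound 3. On these data alone, it is also open whether the same change would give a step of similar size on a different core, such as that of compound 2.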